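Notes on the carbonyl-side aryl substituent in the series

The source may hold more compounds than are shown below. What is called first, only, known or untested is meant among the compounds shown, and "the series" means these compounds.

Of the compounds shown here, three have been measured in a functional assay on MDA-MB-231 cells (Homo sapiens) for cytotoxicity, read by MTT assay, with a stated time of 68 h; a higher number here means a weaker inhibitor, a lower number a stronger inhibitor. Compound 1 `O=C(/C=C/c1cccc(OCc2ccccc2)c1)c1ccccc1Br` gives 1800 nM, compound 2 `O=C(/C=C/c1cccc(OCc2ccccc2)c1)c1ccc(Br)cc1` gives 6400 nM, and compound 3 `COc1ccc(C(=O)/C=C/c2cccc(OCc3ccccc3)c2)cc1` gives 12400 nM. Compound 3 carries the highest number of the three: the step of a 1.9-fold higher number from compound 2 to compound 3 (0.29 log units; within the scatter) stays within the scatter, whereas a 6.9-fold higher number from compound 1 to compound 3 (0.84 log units; beyond the scatter) and a 3.6-fold higher number from compound 1 to compound 2 (0.55 log units; beyond the scatter) lie beyond it.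

Compound 4 `O=C(/C=C/c1cccc(OCc2ccccc2)c1)c1ccc([N+](=O)[O-])cc1` differs from compound 3 by nitro in place of methoxy on an aromatic carbon. Among the compounds with values here, no measured step introduces a nitro group anywhere. Within the data shown here, the only step bearing on the same place is a 1.9-fold higher number from compound 2 to compound 3 (0.29 log units; within the scatter), which stayed within the scatter, so the one exchange made there so far has left the number essentially unmoved. The expected step of a 1.2-fold lower number from compound 3 to compound 4 (0.09 log units; within the scatter) is accordingly none beyond the scatter, in either direction. Compound 4 is estimated at 10000 nM, with a range from 3000 nM to 35000 nM, because compound 3 gives 12400 nM and the nearest comparison a 1.9-fold higher number from compound 2 to compound 3 (0.29 log units; within the scatter) was small.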

Compound 4, half-maximal inhibitory concentration: 23300 nM
Estimate against measurement, compound 4: 2.3-fold (0.37 log units) below, and the stated range covers the measured number.
By their numbers in this assay, from the lowest: compound 1; then compounds 2, 3 and 4 (each within the scatter of the next, the first and the last beyond it).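

Nitro in place of methoxy gives a 1.9-fold higher number from compound 3 to compound 4 (0.27 log units; within the scatter) in this assay and so, like the exchange of bromo for methoxy, stays inside the scatter. Nitro in place of bromo gives a 3.6-fold higher number from compound 2 to compound 4 (0.56 log units; beyond the scatter) and is the first step among the 4-substituted compounds to lie beyond it, so bromo and nitro are not interchangeable here even though methoxy sits within the scatter of each. The step of a 13-fold higher number from compound 1 to compound 4 (1.11 log units; beyond the scatter) is the largest in the series and widens the separation of compound 1, which stays lowest, from the other three.

Open, going by these compounds, is whether an amine or a carboxylic acid in place of the nitro group would stay within the scatter of compound 4, and whether the low number of compound 1 is specific to 2-bromophenyl. No available evidence accounts for these differences.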